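Methylsulfonyl to dimethylsulfamoyl: permeability working notes

The source may report more compounds than this note shows. Statements on the series, on what has been measured and on what is new or still open speak of the compounds shown alone.

Measured so far:
Compound 1 `Cc1cnc(NC(=O)c2cc(Oc3cnc(C(=O)N(C)C)cn3)c3cn(C)nc3c2)cn1` in an ADME assay on MDCKII-LE cells (Canis lupus familiaris) for permeability (a higher number here means that the compound crosses the layer faster, a lower number that the compound crosses the layer more slowly), gives 20.8 10^-6 cm/s.
Compound 2 `Cc1cnc(NC(=O)c2cc(Oc3ccc(S(C)(=O)=O)cc3)c3cn(C)nc3c2)cn1` in this assay gives 20.4 10^-6 cm/s.

Compound 2 stands level with compound 1; the two numbers lie within the scatter of one another, so nothing separates them on the present data. Within the data shown here, no step between measured compounds is available for this series.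

The next compound is compound 3 `Cc1cnc(NC(=O)c2cc(Oc3ccc(S(=O)(=O)N(C)C)cc3)c3cn(C)nc3c2)cn1`. It differs from compound 2 in one place: dimethylamino in place of methyl on a sulfonyl sulfur. Cut one bond further out, the same difference reads methylsulfonyl to dimethylsulfamoyl. The change sits on the sulfonyl sulfur whose other neighbour is an aromatic carbon; the shared core and the amide part are untouched.

Among the measured compounds shown here, with no measured pair of this kind to lean on, the expectation for the step from compound 2 to compound 3 in this assay is none beyond the scatter, at most a small movement in either direction: a 1.0-fold higher number from compound 2 to compound 3 (0.01 log units; within the scatter). Compound 3 is accordingly estimated at 21 10^-6 cm/s, with a range from 10 10^-6 cm/s to 42 10^-6 cm/s.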

Compound 3, apparent permeability: 13.6 10^-6 cm/s
Beside the measured number, compound 3's estimate is 1.5-fold (0.19 log units) above it; measured number inside the range.
By their numbers in this assay, from the lowest: compounds 3, 2 and 1 (each within the scatter of the next).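

The sulfonyl sulfur whose other neighbour is an aromatic carbon now has its first one-place reading, which compounds 1 and 2 alone could not give. In this assay, dimethylamino in place of methyl, with 3 heavy atoms entering where 1 leaves, gives a 1.5-fold lower number from compound 2 to compound 3 (0.18 log units; within the scatter), so on this single pair the change is not separated from repeat-measurement noise, and neither a real loss nor the absence of one is established. No measured information bears on what lies behind this step.

Still open, going by these compounds, is whether any other group on this sulfur would give a step beyond the scatter: an unsubstituted amino group, a cyclic amine such as morpholine, or a longer chain such as ethyl in place of methyl would each test this. One pair also leaves open whether methylsulfonyl to dimethylsulfamoyl would read the same way on another core, or whether repeat measurements of compound 2 and compound 3 would hold the size of this step.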